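Swapping the benzothiazole amide for a nitrothiazole

A few compounds are considered here, and "the series" means these few. Any claim that something is new, unique, unknown or untested is made for them only; others in the source may bear on it.

The series shares one core, shown by compound 1 `O=C(CSc1nnc(COc2ccc3c(c2)CCCC3)o1)Nc1nc2ccc(F)cc2s1` and compound 2 `COc1ccc2nc(NC(=O)CSc3nnc(COc4ccc5c(c4)CCCC5)o3)sc2c1`. In an assay on A549 cells for inhibition of RAC-alpha serine/threonine-protein kinase (Homo sapiens), read by ELISA, with a stated time of 24 h (a lower number here means a stronger inhibitor, a higher number a weaker inhibitor), compound 1 gives 98300 nM, and compound 2 gives 27500 nM. Within the data shown here, the single step measured so far, a 3.6-fold lower number from compound 1 to compound 2 (0.55 log units; beyond the scatter), places compound 2 at the lower of the two numbers in this assay, with compound 1 the only neighbour.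

Compound 3 `O=C(CSc1nnc(COc2ccc3c(c2)CCCC3)o1)Nc1ncc([N+](=O)[O-])s1` differs from compound 2 by 5-nitro-1,3-thiazol-2-yl in place of 6-methoxy-1,3-benzothiazol-2-yl on an amide-type nitrogen. Among the measured compounds shown here, no measured step concerns this part of the molecule; the one known step, a 3.6-fold lower number from compound 1 to compound 2 (0.55 log units; beyond the scatter), touched only a substituent on the ring system that now leaves entirely, so it gives no direct guide. With nothing in the data to anchor the direction, the number for compound 3 in this assay is expected to stay near that of compound 2, with a wide spread, as a 1.5-fold higher number from compound 2 to compound 3 (0.16 log units; within the scatter). The estimate for compound 3 is therefore 40000 nM, between 10000 nM and 150000 nM.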

Compound 3, half-maximal inhibitory concentration: 138000 nM
Estimate against measurement, compound 3: 3.5-fold (0.54 log units) below; the range from low to high includes it.
By their numbers in this assay, from the lowest: compound 2; then compounds 1 and 3 (each within the scatter of the next).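

At this amide-type nitrogen the result in this assay depends on which group leaves: 5-nitro-1,3-thiazol-2-yl in place of 6-methoxy-1,3-benzothiazol-2-yl gives a 5.0-fold higher number from compound 2 to compound 3 (0.70 log units; beyond the scatter) and so loses the standing of compound 2, while the same group in place of 6-fluoro-1,3-benzothiazol-2-yl gives a 1.4-fold higher number from compound 1 to compound 3 (0.15 log units; within the scatter) and so brings no change that can be told apart. The benzothiazole therefore holds no advantage by itself, and only the methoxy form in compound 2 stands apart from the other two. No measurement given here explains why the two replacements differ.

Among these compounds, it stays open whether the nitro group or the single ring sets the number for compound 3, a question that an amino group or a plain hydrogen in place of the nitro group would address. Also open, as far as these compounds go, is whether an ethoxy or a hydroxy group on the benzothiazole would behave like the methoxy group.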